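Swapping the Amide Aryl Group in an Inactive Series

This account rests on a few compounds, and the source may have more. Where it says the series, first, only, none or still open, it means among the compounds named here.

Compound 1 `COc1ccc2c(=O)c(/C=C/C(=O)Nc3ccc(Cl)cc3)coc2c1` belongs to a small set of compounds sharing one core and examined in a functional assay on L02 cells (Homo sapiens) for inhibition, read by MTT assay, with a stated time of 48 h; a lower number here means a stronger inhibitor, a higher number a weaker inhibitor. In this assay compound 1 reaches only the limit, > 200000 nM. Compound 2 `Cc1ccccc1NC(=O)/C=C/c1coc2cc(O)ccc2c1=O` likewise stops at the limit of > 200000 nM in this assay. Compound 3 `O=C(/C=C/c1coc2cc(O)ccc2c1=O)Nc1ccccc1` also gives only the limit, > 200000 nM, in this assay. Going by the values given here, the one step that can be traced between measured compounds, a step that the two limits leave unreadable from compound 2 to compound 3, therefore cannot be sized, and the whole picture rests on (the limit of > 200000 nM in this assay, at which 3 of the 3 values shown sit).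

Compound 4 `COc1ccc2c(=O)c(/C=C/C(=O)Nc3cccc(C)c3)coc2c1` arises from compound 1 through (3-methylphenyl in place of 4-chlorophenyl on an amide-type nitrogen). No measured step touches this part of the molecule, so the recorded values offer no reason to expect a shift beyond the scatter. The step that the limit leaves unreadable from compound 1 to compound 4 is expected to be negligible. Compound 4 is accordingly expected to sit at the limit too, with an estimate of 250000 nM and a range from 100000 nM to 600000 nM.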

Compound 4, half-maximal inhibitory concentration: > 200000 nM
Compound 4: only a limit was reported; the forecaster's own chance of this, stated with the estimate: 85%; the middle value lies beyond the limit too.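

Compound 1 and compound 4 both stop at a limit, so no step can be read between them in this assay: the limit of > 200000 nM in this assay, at which 4 of the 4 values shown sit.

The compounds shown leave open whether 3-methylphenyl and 4-chlorophenyl on the amide-type nitrogen differ at all in this assay.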